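Furfuryl ester in place of propyl: tolerated concentration on HeLa cells

A few compounds are considered here, and "the series" means these few. Any claim that something is new, unique, unknown or untested is made for them only; others in the source may bear on it.

Three esters of the same hydroxy acid on a shared core have been measured in a functional assay on HeLa cells (Homo sapiens) for cytotoxicity; a lower number here means that less compound is tolerated, a higher number that more compound is tolerated. Compound 1 `CCCCOC(=O)C(O)Cn1cnc2c(N)ncnc21` gives 400 ug/mL in this assay. Compound 2 `COCCOC(=O)C(O)Cn1cnc2c(N)ncnc21` reaches only the limit of the assay, reported as > 400 ug/mL. Compound 3 `CCCOC(=O)C(O)Cn1cnc2c(N)ncnc21` likewise stands at the limit, reported as > 400 ug/mL, so for compound 3 only a bound and no number is known. The steps among these three are accordingly open: a number no lower from compound 1 to compound 3 (the limit leaves the size open), a number no lower from compound 1 to compound 2 (the limit leaves the size open), and a step that the two limits leave unreadable from compound 2 to compound 3. The pattern rests on (the limit of > 400 ug/mL in this assay, at which 2 of the 3 values shown sit), which leaves every size unreadable.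

Compound 4 `Nc1ncnc2c1ncn2CC(O)C(=O)OCc1ccco1` is the next ester in this series. Relative to compound 3 the change is furan-2-yl in place of ethyl on a saturated chain carbon bound to an oxygen next to a carbonyl group: the propyl ester becomes a (furan-2-yl)methyl ester, with one five-membered aromatic ring and one hydrogen-bond acceptor entering. For the measured compounds named here, none of the measured steps involves a ring at this position, and none is readable in size, so no direction beyond the scatter is expected; the step from compound 3 to compound 4 is estimated as a number no higher from compound 3 to compound 4 (the limit leaves the size open). Compound 4 is therefore expected to give about 400 ug/mL in this assay, within a range of 200 ug/mL to 800 ug/mL.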

Compound 4, minimum cytotoxic concentration: 40 ug/mL
The estimate for compound 4 lay 10-fold (1.00 log units) above the measured number, and the stated range ends above it.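

In this assay, this place, on a saturated chain carbon bound to an oxygen next to a carbonyl group, proves able to shift the tolerated concentration beyond the scatter: furan-2-yl in place of ethyl gives an at least 10-fold lower number from compound 3 to compound 4 (1.00 log units; beyond the scatter), and furan-2-yl in place of methoxymethyl gives an at least 10-fold lower number from compound 2 to compound 4 (1.00 log units; beyond the scatter). Only the comparison with the butyl ester has a definite size, with furan-2-yl in place of propyl giving a 10-fold lower number from compound 1 to compound 4 (1.00 log units; beyond the scatter), whereas the other two steps are lower bounds. The steps among compounds 1, 2 and 3 still cannot be read, because the assay limit hides their size: the limit of > 400 ug/mL in this assay, at which 2 of the 4 values shown sit.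

Compound 4 is the only ester shown with a ring at this place, so the compounds shown do not separate the effect of the aromatic ring from that of its oxygen, and a benzyl ester or a (tetrahydrofuran-2-yl)methyl ester would bear on that question. On these data alone, whether the lower number belongs to furan-2-yl alone also remains open, since a thiophen-2-yl group or a longer chain such as hexyl has no value here.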